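The source may hold more compounds than are shown below. What is called first, only, known or untested is meant among the compounds shown, and "the series" means these compounds.

In an ADME assay (liver) for metabolic stability, with Liver microsome (Rattus norvegicus) as the target, read by LC-MS, using microsomes, with a stated time of 30 min, tested at 4 uM (a lower number here means that less of the compound is left, a higher number that more of the compound is left), the measured compounds stand as follows:
Compound 1 `COc1cccc(-c2nc3c(N4CCN(C)CC4)nc(C)nc3n2C2CCOCC2)c1`: 30%
Compound 2 `Cc1nc(N2CCN(C)CC2)c2nc(-c3ccccc3C#N)n(C3CCOCC3)c2n1`: 21%

Compound 2 at 21% lies within the scatter of compound 1 at 30% and so holds no clear place of its own. Compound 3 `Cc1nc(N2CCN(C)CC2)c2nc(-c3ccccc3C)n(C3CCOCC3)c2n1` carries methyl in place of cyano on an aromatic carbon, ortho to a large group (methyl in place of cyano on an aromatic carbon). Among the measured compounds shown here, the one measured step at this place is a number 9 percentage points lower from compound 1 to compound 2 (within the scatter) and it stays within the scatter. No change beyond the scatter is therefore expected in this assay for this replacement. The estimated step is a number 2 percentage points higher from compound 2 to compound 3 (within the scatter) in size. Compound 3 is expected at 23% with an estimated range of 10% to 38% in this measurement.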

Compound 3, percent of the compound remaining: 39%
Estimate against measurement, compound 3: 16 percentage points below, and the stated range ends below it.
By their numbers in this assay, from the lowest: compounds 2, 1 and 3 (each within the scatter of the next, the first and the last beyond it).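

In this assay, among the compounds shown here, methyl in place of cyano on this aromatic carbon gives a number 18 percentage points higher from compound 2 to compound 3 (beyond the scatter) and is the only step so far that passes beyond the usual scatter, so the group at this place can shift the percent of compound remaining. By contrast, 2-methylphenyl in place of 3-methoxyphenyl gives a number 9 percentage points higher from compound 1 to compound 3 (within the scatter) and stays within the scatter. On these data alone, whether an amine or a chlorine atom at this place would stand with methyl or with cyano remains open. Nothing at hand explains the step.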